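Methoxy to fluoro on the aryl ether of compound 2

The source may hold more compounds than are shown below. What is called first, only, known or untested is meant among the compounds shown, and "the series" means these compounds.

Of the compounds shown here, two from this series have numbers so far. Compound 1 `COC(=O)c1sc2cccnc2c1Nc1ccc(OC)cc1N` in a functional assay on NCI-H460 cells (Homo sapiens) for inhibition, read by sulforhodamine B assay, with a stated time of 48 h (a lower number here means a stronger inhibitor of growth, a higher number a weaker inhibitor of growth), gives 1000 nM. Compound 2 `COc1cccc(Oc2ccnc3ccsc23)c1` in this assay gives 1040 nM; the two values lie within the scatter of each other, so nothing separates compound 2 from compound 1 on these numbers, and the two cores are different, so no single change links them.

Compound 3 `Fc1cccc(Oc2ccnc3ccsc23)c1` keeps the core of compound 2 and differs from it only here: fluoro in place of methoxy on an aromatic carbon. Among the measured compounds shown here, no pair of measured compounds shows a step of this kind, so the size of the step has no precedent. The expectation is a change that stays within the scatter, with no strong lean in either direction, so that the step from compound 2 to compound 3 is estimated at a 1.1-fold higher number from compound 2 to compound 3 (0.02 log units; within the scatter). Compound 3 is accordingly expected to give 1100 nM in this assay, within a range of 400 nM to 3200 nM.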

Compound 3, concentration for 50% growth inhibition: 103000 nM
Compound 3: middle estimate off by 94-fold (1.97 log units), on the low side; the whole stated range lies below it.
By their numbers in this assay, from the lowest: compounds 1 and 2 (each within the scatter of the next); then compound 3.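

In this assay, among the compounds shown here, this aromatic carbon, meta to a large group, proves highly sensitive to its substituent: fluoro in place of methoxy gives a 99-fold higher number from compound 2 to compound 3 (2.00 log units; beyond the scatter), the only single-place step and a large one. Compound 1 and compound 2 could not show this, since their cores differ and no single change links them. On these numbers, methoxy cannot be exchanged for fluoro here without a large loss of growth inhibition, and no measurement at hand accounts for the size of the step.

Still open, from the compounds shown here alone, is whether the step reflects the departure of methoxy or the arrival of fluoro, and how a hydroxy, an ethoxy or an amine on the same carbon would read. Going by these compounds, whether this sensitivity extends to other positions on the aryl ether also remains open.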